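Three Amides at the Assay Limit, a Fourth Expected There

This account rests on a few compounds, and the source may have more. Where it says the series, first, only, none or still open, it means among the compounds named here.

Compound 1 `COc1ccc2c(=O)c(/C=C/C(=O)Nc3cccc(C)c3)coc2c1`: in a functional assay (QGY7701 cells, Homo sapiens) for inhibition, read by MTT assay, with a stated time of 48 h (a lower number here means a stronger inhibitor, a higher number a weaker inhibitor), compound 1 gives > 100000 nM, a limit of the assay rather than a number.
Compound 2 `COc1ccc2c(=O)c(/C=C/C(=O)NCc3ccccc3)coc2c1`: in this assay compound 2 gives > 100000 nM, again a limit.
Compound 3 `COc1ccc2c(=O)c(/C=C/C(=O)Nc3cc(C)ccc3C)coc2c1`: in this assay compound 3 gives > 100000 nM, also a limit.

Compound 3 therefore stands where every measured compound stands, at the limit of > 100000 nM in this assay, at which 3 of the 3 values shown sit. Because all values are limits, the steps between them cannot be read: a step that the two limits leave unreadable from compound 1 to compound 2, a step that the two limits leave unreadable from compound 1 to compound 3 and a step that the two limits leave unreadable from compound 2 to compound 3 all remain of unknown size.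

Compound 4 `COc1ccc2c(=O)c(/C=C/C(=O)NCc3ccc(F)cc3)coc2c1` differs from compound 3 by 4-fluorobenzyl in place of 2,5-dimethylphenyl on an amide-type nitrogen. Compound 2 already carries a benzyl group on the same nitrogen and is reported only as a limit, so the closest analogue gives no sign that a benzyl-type group brings readable inhibition. For the measured compounds named here, no measured step bears readably on the change, so no step beyond the scatter is expected. The expected step is a step that the limit leaves unreadable from compound 3 to compound 4, essentially none. Compound 4 is estimated at 120000 nM, within 40000 nM to 400000 nM, and is most likely to be reported again as a limit.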

Compound 4, half-maximal inhibitory concentration: 7960 nM
Compound 4: middle estimate off by 15-fold (1.18 log units), on the high side; measured number below the stated range.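

In this assay, a single fluoro on the benzyl group is enough to turn a limit into a readable number, giving an at least 12-fold lower number from compound 2 to compound 4 (1.09 log units; beyond the scatter). The 4-fluorobenzyl group also stands clearly apart from the two aryl groups on the same amide-type nitrogen, with an at least 12-fold lower number from compound 3 to compound 4 (1.09 log units; beyond the scatter) and an at least 12-fold lower number from compound 1 to compound 4 (1.09 log units; beyond the scatter). This shows that the group on this nitrogen can shift the read-out, which the earlier compounds could not show, as each of them sits at the same limit: the limit of > 100000 nM in this assay, at which 3 of the 4 values shown sit.

The steps among compound 1, compound 2 and compound 3 still cannot be read. From the compounds shown here alone, whether chloro, methoxy or trifluoromethyl in place of the fluoro would also give a readable number remains open.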